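The source may report more compounds than this note shows. Statements on the series, on what has been measured and on what is new or still open speak of the compounds shown alone.

Of the compounds shown here, three built on a shared core have been tested in a functional assay on NCI-H1975 cells (Homo sapiens) for inhibition, read by MTT assay, with a stated time of 72 h; on this read-out higher numbers stand for weaker inhibition and lower numbers for stronger inhibition. Compound 1 `O=C(CSc1nc(Nc2ccccc2)c2ccccc2n1)Nc1ccc(Cl)cc1` gives 8040 nM, and compound 2 `O=C(CSc1nc(Nc2ccccc2)c2ccccc2n1)Nc1ccc(C(F)(F)F)cc1` gives 11700 nM. Compound 3 `C=CC(=O)Nc1cccc(NC(=O)CSc2nc(Nc3ccccc3F)c3ccccc3n2)c1` gives 6580 nM in this assay. Compound 3 stands alongside compound 1 and compound 2: all three values lie within the usual scatter of one another, so none can be called stronger or weaker than the others.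

Compound 4 `C=CC(=O)Nc1cccc(NC(=O)CSc2nc(Nc3ccc(F)c(Cl)c3)c3ccccc3n2)c1` is the next compound, not yet measured. It differs from compound 3 in one place: 3-chloro-4-fluorophenyl in place of 2-fluorophenyl on a nitrogen on an aromatic ring.

Among the measured compounds shown here, only one measured step exists, and it changes a different ring: a 1.5-fold higher number from compound 1 to compound 2 (0.16 log units; within the scatter). That step, a swap of one halogen-bearing group for another on an aromatic carbon, did not move the number beyond the scatter. For the measured compounds named here, no measured step touches the ring that changes here, so the expectation rests on that single comparison alone. A step within the scatter is therefore expected, estimated as a 1.0-fold lower number from compound 3 to compound 4 (0.01 log units; within the scatter). Compound 4 is expected to give about 6500 nM, between 2500 nM and 16000 nM.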

Compound 4, half-maximal inhibitory concentration: > 50000 nM
Compound 4 was reported as a limit; the forecaster's own chance of this, stated with the estimate: 5%; middle value at least 7.6-fold (0.88 log units) away from the limit.
By their numbers in this assay, from the lowest: compounds 3, 1 and 2 (each within the scatter of the next). At a limit, above all of these: compound 4.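

Changing the group on this nitrogen can matter a great deal in this assay: 3-chloro-4-fluorophenyl in place of 2-fluorophenyl gives an at least 7.5-fold higher number from compound 3 to compound 4 (0.88 log units; beyond the scatter). Compound 4 gives > 50000 nM, which is a limit of the assay and not a number. Among the compounds shown here, the only earlier step, a 1.5-fold higher number from compound 1 to compound 2 (0.16 log units; within the scatter), changed a different ring and stayed within the scatter, so this is the first sign that a single change on this molecule can clearly weaken inhibition.

The two groups differ both in which halogens they carry and in where those halogens sit, and the compounds shown cannot separate these two differences. On these data alone, it remains open how 3-chlorophenyl, 4-fluorophenyl or a phenyl ring carrying an amine would read on this nitrogen, with the rest of compound 3 kept.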